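A few compounds are considered here, and "the series" means these few. Any claim that something is new, unique, unknown or untested is made for them only; others in the source may bear on it.

Compound 1, `COc1cc(/C=C/C(=O)Nc2ccccc2)cc(OC)c1OC`, in a functional assay on HeLa cells (Homo sapiens) for cytotoxicity, read by sulforhodamine B assay, with a stated time of 72 h; on this read-out lower numbers stand for stronger inhibition and higher numbers for weaker inhibition: > 50000 nM, a limit of the assay.
Compound 2, `COc1ccc(NC(=O)/C=C/c2cc(OC)c(OC)c(OC)c2)cc1`, in this assay: > 50000 nM, a limit of the assay.
Compound 3, `COc1cc(NC(=O)/C=C/c2ccc(O)cc2)cc(OC)c1OC`, in this assay: > 50000 nM, a limit of the assay.

Compound 2 to compound 1 is the change (hydrogen in place of methoxy on an aromatic carbon). Its step, a step that the two limits leave unreadable from compound 2 to compound 1, cannot be sized because of the limit of > 50000 nM in this assay, at which 3 of the 3 values shown sit. The difference between the cores of compound 3 and compound 2 is not broken down here.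

Compound 4, `COc1cc(NC(=O)/C=C/c2ccc(O)cc2)cc(OC)c1`, differs from compound 3 by hydrogen in place of methoxy on an aromatic carbon, the same kind of change as from compound 2 to compound 1, though here the place is ortho to two methoxy groups and para to a large group, whereas before it was only para to a large group.

Compound 4 is expected to give 60000 nM in this assay, between 20000 nM and 200000 nM, most likely again a limit. The expected step that the limit leaves unreadable from compound 3 to compound 4 rests on compound 3 sitting at the limit, because of the limit of > 50000 nM in this assay, at which 3 of the 3 values shown sit.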

Compound 4, half-maximal inhibitory concentration: > 50000 nM
Compound 4: no number, only a limit (the forecaster's own chance of this, stated with the estimate: 85%); the middle value does not contradict the limit.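

No step can be read between compound 3 and compound 4, because both values are limits: the limit of > 50000 nM in this assay, at which 4 of the 4 values shown sit.

The compounds shown leave open whether hydrogen in place of methoxy changes activity at all, and how active any of the four compounds is.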